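The compounds below may be only part of what the source reports. "The series", "measured", "known", "first", "only" and "open" are said of these compounds alone.

Measured so far:
compound 1 `COC(=O)c1c(-c2cc(OC)cc(OC)c2)oc2ccccc2c1=O`: > 25 ug/mL
compound 2 `COC(=O)c1c(-c2ccc(OC)cc2)oc2ccccc2c1=O`: > 25 ug/mL

Both entries come from a functional assay on SK-MEL cells (Homo sapiens) for cytotoxicity, read by MTT assay, with a stated time of 6 days (on this read-out higher numbers stand for an effect only at larger amounts of compound and lower numbers for an effect already at smaller amounts), and both are limits of the assay, not numbers. Compound 2 therefore stands only at its limit of > 25 ug/mL.

Compound 3 `COC(=O)c1c(-c2ccc(Br)cc2)oc2ccccc2c1=O` carries bromo in place of methoxy on an aromatic carbon, para to a large group (bromo in place of methoxy on an aromatic carbon). Going by the values given here, the series holds no measured step for sizing this change. No step beyond the scatter is expected in this assay, in either direction. The expected step is a number no higher from compound 2 to compound 3 (the limit leaves the size open). For compound 3 the estimated value is 25 ug/mL, with an expected range of 10 ug/mL to 40 ug/mL.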

Compound 3, concentration for half-maximal effect: > 25 ug/mL
Compound 3: no number, only a limit; the forecaster's own chance of this, stated with the estimate: 65%; the middle value sits exactly at the limit.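

No step can be read from compound 2 to compound 3, because both stand only at a limit: the limit of > 25 ug/mL in this assay, at which 3 of the 3 values shown sit.

The compounds shown leave open whether bromo in place of methoxy shifts the read-out at all, and which change on the shared core would yield a number.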